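Working notes: quinazoline-free description of a weakly active pair

A few compounds are considered here, and "the series" means these few. Any claim that something is new, unique, unknown or untested is made for them only; others in the source may bear on it.

Measured compounds:
compound 1 `O=C(CSc1nc(Nc2ccccc2)c2ccccc2n1)Nc1cccc(Cl)c1` — 8460 nM
compound 2 `C=CC(=O)Nc1cccc(NC(=O)CSc2nc(Nc3ccccc3C)c3ccccc3n2)c1` — 9920 nM

In a functional assay on NCI-H1975 cells (Homo sapiens) for inhibition, read by MTT assay, with a stated time of 72 h (on this read-out higher numbers stand for weaker inhibition and lower numbers for stronger inhibition), compound 1 gives 8460 nM and compound 2 gives 9920 nM. Compound 2 holds the higher of the two numbers, but its nearest neighbour, compound 1, sits within the scatter, so no order between the two can be read. Going by the values given here, no pair of measured compounds differs in a single place, so no measured step is available to lean on.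

Compound 3 `C=CC(=O)Nc1cccc(NC(=O)CSc2nc(Nc3ccc(Cl)c(Cl)c3)c3ccccc3n2)c1` is not yet measured. Relative to compound 2 it carries 3,4-dichlorophenyl in place of 2-methylphenyl on a nitrogen on an aromatic ring. Among the compounds with values here, with no comparable measured step, the expectation rests on the two numbers alone, both of which lie in the same weak region. The step from compound 2 to compound 3 is expected to be small and likely within the scatter, at about a 1.4-fold lower number from compound 2 to compound 3 (0.15 log units; within the scatter). Compound 3 is thus estimated at 7000 nM, with a range from 2000 nM to 25000 nM.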

Compound 3, half-maximal inhibitory concentration: 19100 nM
Compound 3: the middle estimate sits 2.7-fold (0.44 log units) below what was measured; low and high end bracket the measured number.
By their numbers in this assay, from the lowest: compounds 1, 2 and 3 (each within the scatter of the next, the first and the last beyond it).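

Exchanging 2-methylphenyl for 3,4-dichlorophenyl on a nitrogen on an aromatic ring gives the series its first readable step: in this assay it is a 1.9-fold higher number from compound 2 to compound 3 (0.28 log units; within the scatter) and so does not separate the two groups. At this position, then, a change from one methyl group to two chlorine atoms, with their placement on the phenyl ring also changed, leaves no difference that can be read in this assay. Nothing available bears on why these two compounds read alike.

Going by these compounds, whether a dimethylamino group or a carboxylic acid on this phenyl ring would give a step beyond the scatter stays open. The compounds shown also do not isolate the contribution of the acrylamide group, as no pair among them differs there alone.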